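Phenyl for chloro on the core of compound 1

The compounds below may be only part of what the source reports. "The series", "measured", "known", "first", "only" and "open" are said of these compounds alone.

Going by the values given here, in a functional assay (aorta) for antagonist activity, with Oryctolagus cuniculus as the target (on this read-out higher numbers stand for weaker inhibition and lower numbers for stronger inhibition), compound 1 (`CCCCC1=NC(Cl)=C(C(=O)OCC)C(C)N1Cc1ccc(-c2ccccc2C(=O)O)cc1`) gives 70 nM as the lowest of two numbers so far, and compound 2 (`CCCCC1=NC(Cl)=C(C(=O)OCC)C(c2ccccc2)N1Cc1ccc(-c2ccccc2C(=O)O)cc1`) gives 1000 nM in the same read-out. Among the compounds with values here, the one measured step is a 14-fold higher number from compound 1 to compound 2 (1.15 log units; beyond the scatter) and comes with phenyl in place of methyl on a saturated ring carbon. Compound 3 (`CCCCC1=NC(c2ccccc2)=C(C(=O)OCC)C(C)N1Cc1ccc(-c2ccccc2C(=O)O)cc1`) is not yet measured. It differs from compound 1 by phenyl in place of chloro on a double-bonded ring carbon in a change of phenyl in place of chloro on a double-bonded ring carbon. Within the data shown here, no measured compound varies the chloro, so the phenyl step elsewhere on the ring is a loose guide only. Going by compound 2 at 1000 nM as the only measured phenyl case, a higher number in this assay is expected, probably smaller than that step. The estimated step is a 2.9-fold higher number from compound 1 to compound 3 (0.46 log units; beyond the scatter) and remains uncertain. Compound 3 is expected at 200 nM within a range of 40 nM to 1000 nM in this estimate.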

Compound 3, antagonist equilibrium constant: 630 nM
Beside the measured number, compound 3's estimate is 3.2-fold (0.50 log units) below it; low and high end bracket the measured number.
By their numbers in this assay, from the lowest: compound 1; then compounds 3 and 2 (each within the scatter of the next).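

In this assay, going by these compounds alone, phenyl in place of chloro on the double-bonded ring carbon gives a 9.0-fold higher number from compound 1 to compound 3 (0.95 log units; beyond the scatter) and so shows that this position, not varied in the earlier compounds, responds to the group it carries. Set beside a 14-fold higher number from compound 1 to compound 2 (1.15 log units; beyond the scatter) for phenyl in place of methyl on a saturated ring carbon, this leaves compound 1 with a lower number, beyond the scatter, than both of its phenyl-bearing neighbours, and no compound shown goes against this. No measured property bears on this step, so the data offer no explanation for it.

Only chloro and phenyl are shown at this position, so it remains open whether the higher number comes with the phenyl ring itself or with the loss of the chloro. A methyl, a bromo or an amine on this carbon would help to separate those two readings.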